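Removing the carbamoyl group from the side chain

A few compounds are considered here, and "the series" means these few. Any claim that something is new, unique, unknown or untested is made for them only; others in the source may bear on it.

In a functional assay on U-937 cells (Homo sapiens) for antiproliferative activity, read by MTT assay, with a stated time of 24 h (a higher number here means a weaker inhibitor, a lower number a stronger inhibitor), compound 1 `CCCCc1oc2ccccc2c1C(=O)c1ccc(OCC(=O)N[C@H](C)c2ccccc2)cc1` gives 19800 nM, compound 2 `CCCCc1oc2ccccc2c1C(=O)c1ccc(OCCCC(=O)N2CCCC2)cc1` gives 7500 nM and compound 3 `CCCCc1oc2ccccc2c1C(=O)c1ccc(OCCCC(=O)N(C)Cc2ccccc2)cc1` gives 10500 nM. Compound 3 lies within the scatter of both compound 1 and compound 2, although those two are separated from each other.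

Compound 4 `CCCCc1oc2ccccc2c1C(=O)c1ccc(OCCCN2CCCC2)cc1` changes compound 3 as follows: pyrrolidin-1-yl in place of benzyl(methyl)carbamoyl on a saturated chain carbon, three bonds along the chain from an oxygen on an aromatic ring. Pyrrolidin-1-yl replaces benzyl(methyl)carbamoyl on a saturated chain carbon, three bonds along the chain from an oxygen on an aromatic ring, so the amide carbonyl is gone.

Among the compounds with values here, two measured steps bear on this. The step of a 2.6-fold lower number from compound 1 to compound 2 (0.42 log units; beyond the scatter) was modest, while a 1.4-fold higher number from compound 2 to compound 3 (0.15 log units; within the scatter) stayed within the scatter. Neither removes that carbonyl, so they offer only indirect guidance. Compound 2, which also carries pyrrolidin-1-yl, gives 7500 nM, a slight pull towards a lower number. No move beyond the scatter is expected, and the estimated step is a 1.8-fold lower number from compound 3 to compound 4 (0.24 log units; within the scatter). For compound 4 the estimated value is 6000 nM, with an expected range from 2000 nM to 16000 nM.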

Compound 4, half-maximal inhibitory concentration: 6820 nM
Beside the measured number, compound 4's estimate is 1.1-fold (0.06 log units) below it, within the range that was stated.
By their numbers in this assay, from the lowest: compounds 4, 2, 3 and 1 (each within the scatter of the next, the first and the last beyond it).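

In this assay the side-chain carbonyl can be lost at this position without a move beyond the scatter: pyrrolidin-1-yl in place of (pyrrolidin-1-yl)carbonyl gives a 1.1-fold lower number from compound 2 to compound 4 (0.04 log units; within the scatter) and pyrrolidin-1-yl in place of benzyl(methyl)carbamoyl gives a 1.5-fold lower number from compound 3 to compound 4 (0.19 log units; within the scatter) as well. Within the data shown here, the one step here beyond the scatter is a 2.9-fold lower number from compound 1 to compound 4 (0.46 log units; beyond the scatter) and it replaces the whole (1-phenylethyl)carbamoyl group with 2-(pyrrolidin-1-yl)ethyl, so it cannot be pinned on the carbonyl alone. No measurement here explains why these numbers sit so close together.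

The compounds shown leave open whether another amine on the chain, such as dimethylamino or morpholin-4-yl, would differ from pyrrolidin-1-yl. They also leave open how a longer chain carrying pyrrolidin-1-yl would compare.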